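A few compounds are considered here, and "the series" means these few. Any claim that something is new, unique, unknown or untested is made for them only; others in the source may bear on it.

Working notes on the series built on a shared core carrying an oxy-propyl-oxy chain to a phenyl ring. Compound 1 is `NC1=NC2(CCOCC2)N(OCCCOc2ccc(F)cc2)C(N)=N1` and, in an assay on isolated protein for inhibition of Dihydrofolate reductase (Homo sapiens), read by spectrophotometry, using NADPH, with stated times of 5 s and 6 min (on this read-out lower numbers stand for stronger inhibition and higher numbers for weaker inhibition), compound 1 gives 46.6 nM. Within the data shown here, that is the only number recorded so far: compound 2, `Cc1cc(C)cc(OCCCON2C(N)=NC(N)=NC23CCOCC3)c1`, stands in this assay at "not determined" (no result reported), and compound 3, `NC1=NC2(CCOCC2)N(OCCCOc2cccc(Br)c2)C(N)=N1`, stands in this assay at "not determined" (no result reported). Compound 1 therefore cannot be ranked against anything; it is simply the single anchor the series has in this assay.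

The next entry is compound 4, `CC(C)(C)c1ccc(OCCCON2C(N)=NC(N)=NC23CCOCC3)cc1`, which has not been measured. Its difference from compound 1 is tert-butyl in place of fluoro on an aromatic carbon, on the ring that is para to a large group. Among the measured compounds shown here, no pair of measured compounds shows a single change of this kind, so no size or direction of step can be read off the data, and the comparison to compound 1 is the only footing.

With nothing to lean on beyond that anchor, the expected step from compound 1 to compound 4 in this assay is a 1.3-fold lower number from compound 1 to compound 4 (0.12 log units; within the scatter), small and not clearly beyond the scatter. Compound 4 is thus estimated in this assay at 35 nM, with a range of 9 nM to 140 nM.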

Compound 4, half-maximal inhibitory concentration: 3.72 nM
For compound 4 the middle estimate is 9.4-fold (0.97 log units) above the measured one; measured number outside the range, below it.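

In this assay, tert-butyl in place of fluoro on an aromatic carbon, para to a large group, gives a 13-fold lower number from compound 1 to compound 4 (1.10 log units; beyond the scatter), the first step the series can show, and it establishes that the group at this position matters to the read-out. The entering group has 4 heavy atoms against 1 for the leaving group, and neither has a ring, a hydrogen-bond donor, a hydrogen-bond acceptor or a net charge, so in this one pair the larger group goes with the stronger inhibition. Nothing measured here bears on the reason for this step.

Compound 2 and compound 3 carry no result, so any steps to them cannot be read and compound 4 remains compared with compound 1 alone. Also open, on these data alone, is how an amine, a carboxylic acid or a trifluoromethyl group in the same place would read, and so whether the step follows the count of heavy atoms or belongs to tert-butyl alone.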